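This account rests on a few compounds, and the source may have more. Where it says the series, first, only, none or still open, it means among the compounds named here.

Compound 1 `CCCCCCCCS(=O)(=O)Nc1cc(-c2ccccc2Cl)ccc1C(=O)O` holds the lower of the two numbers recorded so far, though by a margin that falls within the scatter: in an assay on mitochondria (strain BALB/c) for inhibition of glycerol-3-phosphate acyltransferase 1, mitochondrial (Mus musculus), read by scintillation counting, with a stated time of 10 min (a lower number here means a stronger inhibitor, a higher number a weaker inhibitor), compound 1 gives 26900 nM. Compound 2 `CCCCCCCCS(=O)(=O)Nc1ccc(-c2ccc(-c3ccccc3)cc2)cc1C(=O)O` stands close beside it, since in this assay compound 2 gives 29100 nM, so the two cannot be separated. Compound 3 `CCCCCCCCS(=O)(=O)Nc1cc(/C=C/c2ccccc2)ccc1C(=O)O` has not yet been measured in this assay. It differs from compound 1 in one place: 2-phenylethenyl in place of 2-chlorophenyl on an aromatic carbon. For the measured compounds named here, no step between measured compounds exists to guide this change, and compound 1 and compound 2, which differ from each other in more than one place, show only that both sit at the same weak level. The step of a 1.1-fold lower number from compound 1 to compound 3 (0.03 log units; within the scatter) is therefore expected to be small, not clearly beyond the scatter in either direction. Compound 3 is estimated at 25000 nM, with a range from 8000 nM to 80000 nM.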

Compound 3, half-maximal inhibitory concentration: 38000 nM
Beside the measured number, compound 3's estimate is 1.5-fold (0.18 log units) below it; the range from low to high includes it.
By their numbers in this assay, from the lowest: compounds 1, 2 and 3 (each within the scatter of the next).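

In this assay, the position para to a carboxy group now has its first step between measured compounds: 2-phenylethenyl in place of 2-chlorophenyl gives a 1.4-fold higher number from compound 1 to compound 3 (0.15 log units; within the scatter) and so cannot be told apart from no change. The earlier pair differed in more than one place, whereas this step shows that, at this one place, the chlorine can go and a double bond outside aromatic rings can come in with the aromatic ring retained, and the number stays within the scatter. No measurement at hand explains this result.

Going by these compounds, it remains open whether a group of another kind at this position, such as an amine, a carboxylic acid or a morpholine, would move the number beyond the scatter. Equally open, on these data alone, is what a longer chain on the shared core would do.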